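Adding a methyl to the hydroxymethyl of compound 1

This account rests on a few compounds, and the source may have more. Where it says the series, first, only, none or still open, it means among the compounds named here.

Compound 1 `COc1cc(C2Oc3cc(-c4oc5cc(O)cc(O)c5c(=O)c4OC)ccc3OC2CO)ccc1O`: 4900 nM
Compound 2 `COc1cc(O)c2c(=O)c(OC)c(-c3ccc4c(c3)OC(c3ccc(O)c(OC)c3)C(CO)O4)oc2c1`: 8300 nM
Compound 3 `COCC1Oc2ccc(-c3oc4cc(O)cc(O)c4c(=O)c3OC)cc2OC1c1ccc(O)c(OC)c1`: not yet measured

Among the compounds with values here, in a functional assay on HUVEC cells (Homo sapiens) for antiproliferative activity, read by MTT assay, with a stated time of 72 h (a lower number here means a stronger inhibitor, a higher number a weaker inhibitor), only two numbers are available, so compound 1 has a single neighbour, and the two stand level (a 1.7-fold higher number from compound 1 to compound 2 (0.23 log units; within the scatter)). Compound 3 comes from compound 1 by one small edit (methyl in place of hydrogen on an oxygen on a saturated carbon). This is methyl in place of hydrogen on an oxygen on a saturated carbon, which turns hydroxymethyl into methoxymethyl.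

Within the data shown here, only one measured step resembles this edit. It also adds a methyl, but as methyl in place of hydrogen on an oxygen on an aromatic ring, so it sits at a different place. That step, leading to compound 2, stayed within the scatter (a 1.7-fold higher number from compound 1 to compound 2 (0.23 log units; within the scatter)). One step at another place is a thin guide, so no firm direction can be claimed, and no shift beyond the scatter is expected in this assay for this edit. The estimated step is small (a 1.2-fold higher number from compound 1 to compound 3 (0.09 log units; within the scatter)). The value expected for compound 3 is 6000 nM (estimated range 2500 nM to 14000 nM).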

Compound 3, half-maximal inhibitory concentration: 5400 nM
The estimate for compound 3 lay 1.1-fold (0.05 log units) above the measured number, within the range that was stated.
By their numbers in this assay, from the lowest: compounds 1, 3 and 2 (each within the scatter of the next).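

In this assay, putting a methyl in place of the hydrogen on the oxygen of the hydroxymethyl gives a 1.1-fold higher number from compound 1 to compound 3 (0.04 log units; within the scatter), so this small edit leaves the two compounds level. Within the data shown here, until now, the only methyl step measured sat on an oxygen on an aromatic ring, so this is the first direct reading at the oxygen on a saturated carbon, and it shows that hydroxymethyl and methoxymethyl cannot be told apart in this assay; with a 1.7-fold higher number from compound 1 to compound 2 (0.23 log units; within the scatter) also printed as within the scatter, neither single methyl step from compound 1 moves the number beyond it. No available evidence explains why the methoxymethyl compound stands level with the hydroxymethyl compound.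

The compounds shown cover only the addition of one methyl at this position, so they leave open whether a longer chain on the same oxygen, such as ethyl or propyl, would also stay level. They also leave open what an amine or a carboxylic acid would do in place of the hydroxymethyl, which could show whether this position tolerates larger or different groups as well.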